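The source may report more compounds than this note shows. Statements on the series, on what has been measured and on what is new or still open speak of the compounds shown alone.

Measured in an ADME assay on L1210 cells (Mus musculus) for cytotoxicity, with a stated time of 48 h; a lower number here means a stronger inhibitor, a higher number a weaker inhibitor:
- Compound 1 `C=C1[C@H](C)CCC[C@]1(C)CC/C(C)=C/CC1=C(O)C(=O)C=C(N[C@@H](C(=O)O)C(C)C)C1=O`: 3.4 ug/mL
- Compound 2 `C=C1[C@H](C)CCC[C@]1(C)CC/C(C)=C/CC1=C(O)C(=O)C=C(N[C@H](C(=O)O)[C@@H](C)O)C1=O`: > 10 ug/mL

Compound 2 gives > 10 ug/mL, which is a limit of the assay and not a number. Among the measured compounds shown here, only one measured step bears on it: an at least 2.9-fold higher number from compound 1 to compound 2 (0.46 log units; beyond the scatter), where 1-carboxy-2-hydroxypropyl replaces 1-carboxy-2-methylpropyl on an amine nitrogen. Compound 3 `C=C1[C@H](C)CCC[C@]1(C)CC/C(C)=C/CC1=C(O)C(=O)C=C(N[C@@H](C(=O)O)[C@@H](C)O)C1=O` has not yet been measured. Its difference from compound 2 is this: the two compounds have the same atoms and bonds and differ only in configuration as drawn: 1 of 5 stereo elements differ; a stereocentre at a saturated chain carbon is drawn S in compound 2 and R in compound 3.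

For the measured compounds named here, no measured step tests a change of configuration, so any forecast here is uncertain. Going by the values given here, the step to compound 2, an at least 2.9-fold higher number from compound 1 to compound 2 (0.46 log units; beyond the scatter), is the only guide, and it changes the group itself. Compound 3 is therefore expected to stay close to compound 2 in this assay, with no step beyond the scatter, and it may well stop at the same limit. The expected change is an at least 1.1-fold lower number from compound 2 to compound 3 (0.04 log units; that floor lies within the scatter). The estimate for compound 3 is 9 ug/mL, with an expected range from 3.5 ug/mL to 20 ug/mL.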

Compound 3, half-maximal inhibitory concentration: > 10 ug/mL
Compound 3 ended at the assay's limit; the forecaster's own chance of this, stated with the estimate: 55%; at least 1.1-fold (0.04 log units) between middle value and limit.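

The other drawn configuration of the hydroxyl-bearing carbon also falls short of compound 1: in this assay, 1-hydroxyethyl in place of isopropyl on a saturated chain carbon bound to an amine nitrogen and a carbonyl carbon gives an at least 2.9-fold higher number from compound 1 to compound 3 (0.46 log units; beyond the scatter). The loss seen with compound 2 is therefore not confined to one configuration at this stereocentre, and this pair isolates a single change: the fact that compounds 2 and 3 differ only in the configuration as drawn. Still, the step from compound 2 to compound 3 cannot be read, so any effect of that change stays hidden: the limit of > 10 ug/mL in this assay, at which 2 of the 3 values shown sit.

As far as these compounds go, how far compounds 2 and 3 lie beyond that limit remains open, as does any ranking of the two. From the compounds shown here alone, it is also open whether a 1-methoxyethyl group at this place would behave like 1-hydroxyethyl or like isopropyl.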